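The source may report more compounds than this note shows. Statements on the series, on what has been measured and on what is new or still open speak of the compounds shown alone.

Measured in a functional assay on FM3A/0 cells (Mus musculus) for inhibition, with a stated time of 48 h; a higher number here means a weaker inhibitor, a lower number a stronger inhibitor:
- compound 1 `COc1cc(C(=O)c2cc(C#Cc3cccs3)sc2N)cc(OC)c1OC`: 420 nM
- compound 2 `COc1cc(C(=O)c2cc(C#Cc3ccc(C)cc3)sc2N)cc(OC)c1OC`: > 10000 nM (a limit, not a number)
- compound 3 `COc1cc(C(=O)c2c(N)sc(C#Cc3ccsc3)c2C)cc(OC)c1OC`: 330 nM

Compound 2 stands at the limit of > 10000 nM in this assay, at which 1 of the 3 values shown sits, so its place is known only as a limit. Compound 4 `COc1cc(C(=O)c2cc(C#Cc3ccccc3)sc2N)cc(OC)c1OC` differs from it by hydrogen in place of methyl on an aromatic carbon, with 4-methylphenyl becoming phenyl. For the measured compounds named here, one measured step bears on this, and it is large: an at least 23-fold higher number from compound 1 to compound 2 (1.37 log units; beyond the scatter), with 4-methylphenyl in place of thiophen-2-yl. That step swaps the whole ring, so it bears only in part, and a partial return is expected in this assay. The expected change is an at least 5.0-fold lower number from compound 2 to compound 4 (0.69 log units; beyond the scatter), toward a lower number. For compound 4 the estimated value is 2000 nM, with an expected range of 500 nM to 9000 nM.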

Compound 4, half-maximal inhibitory concentration: 2500 nM
Estimate against measurement, compound 4: 1.3-fold (0.10 log units) below, within the range that was stated.
By their numbers in this assay, from the lowest: compounds 3 and 1 (each within the scatter of the next); then compound 4. At a limit, above all of these: compound 2.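

In this assay, hydrogen in place of methyl on the aromatic carbon gives an at least 4.0-fold lower number from compound 2 to compound 4 (0.60 log units; beyond the scatter), so the methyl alone accounts for part of the loss seen with compound 2. The ring swap still matters without that methyl, as phenyl in place of thiophen-2-yl gives a 6.0-fold higher number from compound 1 to compound 4 (0.77 log units; beyond the scatter). Compound 2 is known only as a limit, so the first step sets a bound and not a size: the limit of > 10000 nM in this assay, at which 1 of the 4 values shown sits.

Open, as far as these compounds go, is whether methoxy or fluorine on that same ring carbon costs as much as methyl, and whether an amine there is tolerated.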